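A Second Isopropyl on the Aryloxy Ring

The source may report more compounds than this note shows. Statements on the series, on what has been measured and on what is new or still open speak of the compounds shown alone.

Compound 1 `O=C(COc1ccccc1)Nc1nc(-c2ccc(Br)cc2)cs1` is the plainest member of the set; in a functional assay on MCF7 cells (Homo sapiens) for cytotoxicity, read by trypan blue exclusion, with a stated time of 48 h (a lower number here means a stronger inhibitor, a higher number a weaker inhibitor), compound 1 gives 54000 nM. Compound 2 `CC(C)c1ccccc1OCC(=O)Nc1nc(-c2ccc(Br)cc2)cs1` differs from it by isopropyl in place of hydrogen on an aromatic carbon, and the step is a 1.2-fold lower number from compound 1 to compound 2 (0.09 log units; within the scatter), so that compound 2 gives 43500 nM. Compound 3 `CC(C)c1ccccc1OCC(=O)Nc1nc(-c2ccc(Cl)cc2)cs1` carries chloro in place of bromo on an aromatic carbon, and the step of a 2.4-fold lower number from compound 2 to compound 3 (0.38 log units; beyond the scatter) brings compound 3 to 18100 nM, the lowest number of the three and beyond the scatter from both others. The difference between the cores of compound 1 and compound 3 is not broken down here.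

Compound 4 `CC(C)c1ccc(OCC(=O)Nc2nc(-c3ccc(Cl)cc3)cs2)c(C(C)C)c1` has not been measured. Relative to compound 3 it carries isopropyl in place of hydrogen on an aromatic carbon. Going by the values given here, this is the same kind of change as the one made between compound 1 and compound 2, not the same change: there the new group stood ortho to a large group, here it stands meta to an isopropyl group and para to a large group. The earlier step was a 1.2-fold lower number from compound 1 to compound 2 (0.09 log units; within the scatter), within the scatter. Because of that step a 1.2-fold lower number from compound 1 to compound 2 (0.09 log units; within the scatter), compound 4 is expected to show a step of similar size, a 1.2-fold lower number from compound 3 to compound 4 (0.08 log units; within the scatter). Compound 4 is thus estimated to give 15000 nM in this assay, with a range from 6000 nM to 40000 nM. Whether a second isopropyl behaves like the first is not shown by these three compounds alone.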

Compound 4, half-maximal inhibitory concentration: 40600 nM
Estimate against measurement, compound 4: 2.7-fold (0.43 log units) below, and the stated range ends below it.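

In this assay the added isopropyl gave a 2.2-fold higher number from compound 3 to compound 4 (0.35 log units; beyond the scatter), so the step seen earlier did not carry over from one core to the other: the same change on two cores in this assay, a 1.2-fold lower number (0.09 log units; within the scatter) from compound 1 to compound 2 and a 2.2-fold higher number (0.35 log units; beyond the scatter) from compound 3 to compound 4, 2.8-fold (0.44 log units) apart, beyond the scatter of two such steps

Within this series, then, the isopropyl step measured on one core was no safe guide to the size or the direction of the step on another. What the comparison does not show is why the two steps part. They differ at once in the core and in the place of the new group, which in compound 4 stands meta to an isopropyl group and para to a large group, and a single pair on each side cannot separate these two differences.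

The compounds shown leave open how a second isopropyl would behave on the core of compound 2, which carries bromo in place of chloro, and so whether the halogen has any share in the difference. They also leave open whether a methyl group at the same place, or a group of another kind such as an amine or a carboxylic acid, would move the number in the same direction as isopropyl.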